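The source may report more compounds than this note shows. Statements on the series, on what has been measured and on what is new or still open speak of the compounds shown alone.

Compound 1, `C=CCn1c(=O)c2nc(-c3ccc(Cl)cc3N)[nH]c2n(CC=C)c1=O`, gives 0.8 nM in an assay for binding affinity to adenosine receptor A1 (Bos taurus); on this read-out lower numbers stand for stronger inhibition and higher numbers for weaker inhibition.
Compound 2, `CCc1ccc(-c2nc3c(=O)n(C)c(=O)n(C)c3[nH]2)cc1`, gives 0.8 nM in this assay.
Compound 3, `Cn1c(=O)c2nc(-c3cccc([N+](=O)[O-])c3)[nH]c2n(C)c1=O`, gives 50 nM in this assay.

On these three numbers compound 2 stands level with compound 1 at the digits shown, the two of them together at the low end of the set; the difference between them is within the scatter, so no order can be read from it. Compound 3 sits far from both, its number being well beyond the scatter above that of compound 2.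

The next compound, compound 4, `CN(C)c1ccc(-c2nc3c(=O)n(C)c(=O)n(C)c3[nH]2)cc1`, is not yet measured. It differs from compound 2 in one place: dimethylamino in place of ethyl on an aromatic carbon. The ring of carbon only is kept, as is the shared core; only the group on that aromatic carbon changes.

Going by the values given here, no step between two measured compounds shows what such a replacement does here, so the expectation for compound 4 rests on its closeness to compound 2 alone. Because compound 2 gives 0.8 nM, a small loss is expected, so the step of a 3.8-fold higher number from compound 2 to compound 4 (0.57 log units; beyond the scatter) in this assay is estimated to be modest and toward weaker inhibition, with a real chance it stays within the scatter. Compound 4 is therefore expected to give about 3 nM, between 0.8 nM and 15 nM.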

Compound 4, half-maximal inhibitory concentration: 1.8 nM
The estimate for compound 4 lay 1.7-fold (0.22 log units) above the measured number; the range from low to high includes it.
By their numbers in this assay, from the lowest: compounds 1 and 2 (each within the scatter of the next); then compound 4; then compound 3.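

In this assay, going by these compounds alone, the one step that can be read at this position, on an aromatic carbon para to a large group, is a 2.3-fold higher number from compound 2 to compound 4 (0.35 log units; beyond the scatter), for dimethylamino in place of ethyl. The position therefore accepts this exchange, which brings in a nitrogen and a hydrogen-bond acceptor, at a modest cost, with compound 4 still giving 1.8 nM. Nothing available here accounts for this step, so it stands as an observation only.

The compounds shown leave open whether the nitrogen or the two methyl groups on it matter more, as a primary amine, a methoxy group or a longer chain such as propyl at the same aromatic carbon could help to tell. They also leave open whether dimethylamino in place of ethyl would give a step of similar size on a core carrying the allyl groups of compound 1.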